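The source may report more compounds than this note shows. Statements on the series, on what has been measured and on what is new or still open speak of the compounds shown alone.

Compound 1 `N=C(N)N/N=C(/C=C/c1ccc(F)cc1)c1ccccc1` gives 2500 nM
Compound 2 `N=C(N)N/N=C(/C=C/c1ccc(Cl)cc1)c1ccccc1` gives 700 nM
Compound 3 `N=C(N)N/N=C(/C=C/c1ccccc1)c1ccccc1` gives 17000 nM

In a functional assay on MCF7 cells (Homo sapiens) for antiproliferative activity, read by MTT assay, with a stated time of 48 h (a higher number here means a weaker inhibitor, a lower number a stronger inhibitor), compound 3 has the highest number of the three (17000 nM) and is thus the weakest inhibitor measured so far. Compound 4 `N=C(N)N/N=C(/C=C/c1ccc(-c2ccccc2)cc1)c1ccccc1` differs from it by one change, phenyl in place of hydrogen on an aromatic carbon. Within the data shown here, no measured compound carries phenyl, so the nearest evidence comes from the two steps linking compound 3 to its halogen-bearing relatives. The modest step of a 6.8-fold higher number from compound 1 to compound 3 (0.83 log units; beyond the scatter) and the large step of a 24-fold higher number from compound 2 to compound 3 (1.39 log units; beyond the scatter) both show a higher number with hydrogen than with a halogen. The halogens themselves are also apart, with a 3.6-fold lower number from compound 1 to compound 2 (0.55 log units; beyond the scatter) beyond the scatter. Both steps run the same way, but they cover only fluoro and chloro and say nothing direct about an added ring. A lower number than that of compound 3 is therefore expected for compound 4, with a step of modest to large size and considerable uncertainty. The expected change is an 8.5-fold lower number from compound 3 to compound 4 (0.93 log units; beyond the scatter) in this assay on this reading. Compound 4 is estimated at 2000 nM (expected range 300 nM to 12000 nM).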

Compound 4, half-maximal inhibitory concentration: 800 nM
Compound 4: middle estimate off by 2.5-fold (0.40 log units), on the high side; the measured number falls inside the stated range.
By their numbers in this assay, from the lowest: compounds 2 and 4 (each within the scatter of the next); then compound 1; then compound 3.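

The earlier compounds shown here showed this position only with hydrogen, fluoro or chloro, and compound 4 extends the picture to a whole ring of 6 heavy atoms on the same aromatic carbon: in this assay the phenyl group brings a 21-fold lower number from compound 3 to compound 4 (1.33 log units; beyond the scatter) and is clearly accepted there. Phenyl and chloro cannot be told apart at this position, with a 1.1-fold higher number from compound 2 to compound 4 (0.06 log units; within the scatter), while phenyl in place of fluoro gives a 3.1-fold lower number from compound 1 to compound 4 (0.49 log units; beyond the scatter), so the response does not separate the substituents simply by the number of heavy atoms they carry. The compounds shown offer no independent measurement that would explain this result.

From the compounds shown here alone, all of these changes sit at one position of the shared core, so it remains open whether an amine, a carboxylic acid or a methoxy group would be accepted there as well. Going by these compounds, it is equally open how a longer chain such as butyl, or a second ring bearing its own chloro group, would compare with phenyl, and whether any of these would go beyond the level of the two best-matched compounds here.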